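Swapping Methylsulfonyl for Trifluoromethyl on an HDAC6 Inhibitor

The compounds below may be only part of what the source reports. "The series", "measured", "known", "first", "only" and "open" are said of these compounds alone.

Compound 1 `O=C(NO)c1ccc(NC2CCN(c3ccc(Cl)cc3)C2=O)cc1F`: "not determined" (no result reported)
Compound 2 `CS(=O)(=O)c1ccc(N2CCC(Nc3ccc(C(=O)NO)cc3)C2=O)cc1`: 140 nM

Among the compounds with values here, compound 2 is the only compound here with a number: in an assay on isolated protein for inhibition of protein deacetylase HDAC6 (Homo sapiens) (a lower number here means a stronger inhibitor, a higher number a weaker inhibitor), compound 2 gives 140 nM, while compound 1 gave no result. Compound 3 `O=C(NO)c1ccc(NC2CCN(c3ccc(C(F)(F)F)cc3)C2=O)cc1` differs from compound 2 in one place: trifluoromethyl in place of methylsulfonyl on an aromatic carbon. Within the data shown here, no measured pair shows what this change does, so its effect is unknown. A small shift in this assay, within the scatter and in no firm direction, is expected. Compound 3 is therefore estimated at 170 nM, with a range from 60 nM to 500 nM. The expected step is a 1.2-fold higher number from compound 2 to compound 3 (0.08 log units; within the scatter).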

Compound 3, half-maximal inhibitory concentration in the protein deacetylase HDAC6 assay: 250 nM
Beside the measured number, compound 3's estimate is 1.5-fold (0.17 log units) below it, and the stated range covers the measured number.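

At this place on the aromatic ring, para to a large group, methylsulfonyl can give way to trifluoromethyl with no firm change in the protein deacetylase HDAC6 assay: a 1.8-fold higher number from compound 2 to compound 3 (0.25 log units; within the scatter). In a physicochemical assay for solubility, in phosphate buffer (on this read-out higher numbers stand for higher solubility and lower numbers for lower solubility), compound 2 gives 97 ug/mL and compound 3 gives 43 ug/mL. The swap therefore costs solubility more clearly than it shifts inhibition: the measured solubility of compound 2, 97 ug/mL, and of compound 3, 43 ug/mL, a 2.3-fold lower number (0.35 log units; beyond the scatter)

On these data alone, whether a different group at this place, such as a nitrile or a carboxylic acid, would keep the inhibition while giving higher solubility remains open.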